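Swapping a Bromophenyl Ring for a Benzyloxy Chain

The source may hold more compounds than are shown below. What is called first, only, known or untested is meant among the compounds shown, and "the series" means these compounds.

Of the compounds shown here, three built on one shared core have been tested in a functional assay on the whole organism (plasma) with Mus musculus as the target, with a stated time of 15 days, at a dose of 10 mg/kg by the oral route; a higher number here means a stronger effect of the compound at the dose given, a lower number a weaker effect. Compound 1 `Cc1ccc(CN2C(=O)S/C(=C\c3ccccc3Cl)C2=O)cc1` gives 14.8%. Compound 2 `Cc1ccc(CN2C(=O)S/C(=C\c3cccc(Br)c3)C2=O)cc1` gives 17.6%, which puts it second highest of the three numbers; its gap to compound 1 lies within the scatter, while its gap to compound 3 lies beyond it. Compound 3 `COc1ccc(/C=C2\SC(=O)N(Cc3ccc(C)cc3)C2=O)c(OC)c1` gives 40%.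

Compound 4 `Cc1ccc(CN2C(=O)S/C(=C\OCc3ccccc3)C2=O)cc1` is not yet measured. It differs from compound 2 in one place: benzyloxy in place of 3-bromophenyl on a double-bonded chain carbon bound to a double-bonded ring carbon. Within the data shown here, the only measured step at that same place is a number 2.8 percentage points higher from compound 1 to compound 2 (within the scatter), which exchanges one halogen-bearing ring for another and stays within the scatter. Among the measured compounds shown here, no measured step exchanges an aromatic ring for a benzyloxy chain, so that small step is the only direct guide. The gap between compound 2 and compound 3 shows that a change at this place can move the number beyond the scatter, but that change is a different one.

The expected step is therefore a number 0.4 percentage points higher from compound 2 to compound 4 (within the scatter), with wide uncertainty. Compound 4 is estimated to give 18%, within a range from 5% to 35%.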

Compound 4, a percentage reported as activity, at one dose (the size of the read-out at that dose, not a potency): 43.6%
Compound 4: the middle estimate sits 25.6 percentage points below what was measured; the measured number lies above the stated range.
By their numbers in this assay, from the lowest: compounds 1 and 2 (each within the scatter of the next); then compounds 3 and 4 (each within the scatter of the next).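

In this assay the exchange of one halogen-bearing ring for another stayed within the scatter, so that step alone suggested little sensitivity to ring exchanges at this place. Benzyloxy in place of 3-bromophenyl gives a number 26 percentage points higher from compound 2 to compound 4 (beyond the scatter) and benzyloxy in place of 2-chlorophenyl gives a number 28.8 percentage points higher from compound 1 to compound 4 (beyond the scatter) on the same shared core. A change of group on the double-bonded chain carbon bound to a double-bonded ring carbon can therefore move the number well beyond the scatter, here with a group that adds an oxygen counted as a hydrogen-bond acceptor and carries no halogen.

From the compounds shown here alone, these compounds do not separate the oxygen from the rest of the benzyloxy group, and how an amine or a longer chain at this place would read in this assay remains open. No measurement shown accounts for the rise.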